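Solubility of a Piperidine Analogue Expected From a Limit

The source may report more compounds than this note shows. Statements on the series, on what has been measured and on what is new or still open speak of the compounds shown alone.

Of the compounds shown here, three of one shared core have been measured in a physicochemical assay for solubility, read by HPLC, in phosphate buffer, measured as kinetic solubility, with a stated time of 1 h, at pH 7.4, tested at 250 uM; a lower number here means a less soluble compound, a higher number a more soluble compound. Compound 1, `CC(C)CNC(=O)n1c(=O)oc2ccc(C3CCN(C)CC3)cc21`, gives 60000 nM. Compound 3, `CN1CCC(c2ccc3c(c2)oc(=O)n3C(=O)NCCCCc2ccc(F)cc2)CC1`, gives 22000 nM. Compound 2, `CN1CCN(c2ccc3c(c2)oc(=O)n3C(=O)NCCCCc2ccccc2)CC1=O`, gives only < 1000 nM, which is a limit of the assay rather than a number, (the limit of < 1000 nM in this assay, at which 1 of the 3 values shown sits). So compound 2 stands at the bottom edge of what was measured, with no number of its own, while compound 1 and compound 3 each have a real value.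

The next compound, compound 4, `CC(C)CN1CCC(c2ccc3c(c2)oc(=O)n3C(=O)NCCCCc2ccccc2)CC1`, has not been measured. It differs from compound 2 in one place: 1-isobutylpiperidin-4-yl in place of 4-methyl-3-oxopiperazin-1-yl on an aromatic carbon. The group that enters carries the same piperidine ring that compound 1 and compound 3 carry, with an isobutyl group on its nitrogen in place of their methyl.

Among the measured compounds shown here, no measured step covers this exact change, so the expectation rests on the values of compound 1 and compound 3. Compound 4 is expected to rise clearly above the limit, with a step of an at least 15-fold higher number from compound 2 to compound 4 (1.17 log units; beyond the scatter). The estimate for compound 4 in this assay is 15000 nM, with a range from 3000 nM to 60000 nM.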

Compound 4, solubility: < 1000 nM
Compound 4: no number, only a limit (the forecaster's own chance of this, stated with the estimate: 15%); middle value at least 15-fold (1.17 log units) from the limit.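

In this assay compound 4 gives < 1000 nM, which is a limit of the assay and not a number. Compound 2 also has only a limit, so no step between compound 2 and compound 4 can be read: the limit of < 1000 nM in this assay, at which 2 of the 4 values shown sit.

Still open, going by these compounds, is how far 1-isobutylpiperidin-4-yl in place of 4-methyl-3-oxopiperazin-1-yl changes the true value, since neither compound has a number of its own.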